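The compounds below may be only part of what the source reports. "The series", "measured", "known", "first", "only" and "open" are said of these compounds alone.

Measured so far:
compound 1, `C#CCOc1ccc(C(C)(C)C)cc1C1(c2ccccc2)C(=O)Nc2ccccc21`: > 20000 nM
compound 2, `CN(C)c1ccc(C2(c3cc(C(C)(C)C)ccc3O)C(=O)Nc3ccccc32)cc1`: 10900 nM

Both were tested in a functional assay on cells (Mus musculus) for antiproliferative activity, read by sulforhodamine B assay, with a stated time of 5 days; on this read-out higher numbers stand for weaker inhibition and lower numbers for stronger inhibition. For compound 1 the recorded > 20000 nM is a limit of the assay rather than a number, as noted in the limit of > 20000 nM in this assay, at which 1 of the 2 values shown sits. Compound 2 stands as the only numerical result so far, with 10900 nM in this assay. Among the compounds with values here, the one further value shown, that of compound 1, is a limit. Compound 3, `CC(C)(C)c1ccc(O)c(C2(c3cccnc3)C(=O)Nc3ccccc32)c1`, has not yet been measured. It differs from compound 2 in one place: pyridin-3-yl in place of 4-(dimethylamino)phenyl on a saturated ring carbon. Within the data shown here, no step between two measured compounds is available to guide the expectation, so the size of the change in this assay is uncertain; a shift beyond the usual scatter toward weaker inhibition seems somewhat more likely than a gain, though a result within scatter of compound 2 is also plausible. The expected step from compound 2 to compound 3 is a 1.5-fold higher number from compound 2 to compound 3 (0.17 log units; within the scatter). Compound 3 is estimated at 16000 nM, within a range from 5000 nM to 60000 nM.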

Compound 3, half-maximal inhibitory concentration: > 20000 nM
Compound 3: only a limit was reported; the forecaster's own chance of this, stated with the estimate: 45%; middle value at least 1.2-fold (0.09 log units) away from the limit.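

Compound 3 gives > 20000 nM in this assay, which is a limit of the assay and not a number. Within the data shown here, putting pyridin-3-yl in place of 4-(dimethylamino)phenyl on this saturated ring carbon gives an at least 1.8-fold higher number from compound 2 to compound 3 (0.26 log units; that floor lies within the scatter), the first step that can be read at this position. The true size of the change stays unknown, and a shift beyond the usual scatter cannot be claimed because most of the results rest at the same ceiling: the limit of > 20000 nM in this assay, at which 2 of the 3 values shown sit.

The compounds shown do not separate the removal of the dimethylamino group from the entry of a nitrogen into the aromatic ring. On these data alone, it also remains open whether a methoxy group or a carboxylic acid in place of the dimethylamino group would give a measurable number in this assay.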